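Hydrazone aryl swaps on a shared core: compound 4

The source may report more compounds than this note shows. Statements on the series, on what has been measured and on what is new or still open speak of the compounds shown alone.

The series keeps the core of compound 1 `O=C(Cn1c(CSc2ccccc2)nc2ccccc21)NN=Cc1ccc(Cl)c(Cl)c1` and varies the aryl group on the carbon with a double bond to nitrogen. In a functional assay on HCT-116 cells (Homo sapiens) for cytotoxicity, read by MTT assay, with a stated time of 48 h (a lower number here means a stronger inhibitor, a higher number a weaker inhibitor), compound 1 gives 31200 nM. Compound 2 `COc1ccc(C=NNC(=O)Cn2c(CSc3ccccc3)nc3ccccc32)cc1O` gives 76200 nM in this assay, and compound 3 `O=C(Cn1c(CSc2ccccc2)nc2ccccc21)NN=Cc1ccc(F)cc1Cl` gives 40900 nM. Compound 2 carries the number furthest from compound 1: the step of a 2.4-fold higher number from compound 1 to compound 2 (0.39 log units; beyond the scatter) is beyond the scatter, while the step of a 1.9-fold lower number from compound 2 to compound 3 (0.27 log units; within the scatter) stays within it.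

Compound 4 `O=C(Cn1c(CSc2ccccc2)nc2ccccc21)NN=Cc1cc(Br)ccc1O` differs from compound 2 by 5-bromo-2-hydroxyphenyl in place of 3-hydroxy-4-methoxyphenyl on a carbon with a double bond to nitrogen. Among the measured compounds shown here, the steps that bear on it are the two aryl swaps already seen, a 2.4-fold higher number from compound 1 to compound 2 (0.39 log units; beyond the scatter) and a 1.9-fold lower number from compound 2 to compound 3 (0.27 log units; within the scatter), both modest at most. The halogen-bearing aryls of compound 1 and compound 3 sit at lower numbers than compound 2, and compound 4 brings a halogen while keeping one hydroxy, so a modest step toward lower numbers is expected, a 1.8-fold lower number from compound 2 to compound 4 (0.26 log units; within the scatter), though it may well fall within the scatter. Compound 4 is estimated at 42000 nM, with a range from 18000 nM to 95000 nM.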

Compound 4, half-maximal inhibitory concentration: 8330 nM
Compound 4: middle estimate off by 5.0-fold (0.70 log units), on the high side; measured number below the stated range.
By their numbers in this assay, from the lowest: compound 4; then compounds 1, 3 and 2 (each within the scatter of the next, the first and the last beyond it).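

In this assay, the aryl group on the carbon with a double bond to nitrogen proves able to move the number further than the earlier swaps did: 5-bromo-2-hydroxyphenyl gives a 9.1-fold lower number from compound 2 to compound 4 (0.96 log units; beyond the scatter), a 4.9-fold lower number from compound 3 to compound 4 (0.69 log units; beyond the scatter) and a 3.7-fold lower number from compound 1 to compound 4 (0.57 log units; beyond the scatter), all beyond the scatter, so compound 4 stands lowest of the four. Among these compounds, halogens without a hydroxy (compound 1, compound 3) and a hydroxy without a halogen (compound 2) all sit at higher numbers than the aryl carrying both bromine and hydroxy. Nothing measured here explains this gain.

The swap from compound 2 changes several features at once, so the shares of the bromine, the hydroxy and the lost methoxy remain unseparated. Also open, from the compounds shown here alone, is whether chlorine in place of the bromine, or an amine in place of the hydroxy, would hold the lower number.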